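This account rests on a few compounds, and the source may have more. Where it says the series, first, only, none or still open, it means among the compounds named here.

Of the compounds shown here, two have been measured in an assay on isolated protein for inhibition of beta-glucuronidase (Bos taurus), read by spectrophotometry, with a stated time of 30 min; a higher number here means a weaker inhibitor, a lower number a stronger inhibitor. Compound 1 `Cc1ccc(Nc2nnc(-c3ccc(C(C)(C)C)cc3)s2)cc1` gives 26300 nM in this assay. Compound 2 `Brc1ccc(-c2nnc(Nc3ccccc3)s2)cc1` gives 40200 nM in this assay. For the measured compounds named here, of the two numbers, the one for compound 2 is the larger, but its gap to compound 1 lies within the usual scatter of such measurements, so the two cannot be separated on these data.

Compound 3 `Cc1ccc(Nc2nnc(-c3ccc(Br)cc3)s2)cc1` has not yet been measured. Compared with compound 2, the change is methyl in place of hydrogen on an aromatic carbon. Compound 1 also carries a methyl on its aniline ring, and its number lies close to that of compound 2, which suggests that this methyl by itself does not move the read-out much, though compound 1 and compound 2 differ in a second place as well, so this is only an indication. Going by the values given here, no measured pair isolates the methyl alone. The step of a 1.3-fold lower number from compound 2 to compound 3 (0.10 log units; within the scatter) is therefore expected to be small and to stay within the scatter, in no particular direction. Compound 3 is estimated at 32000 nM in this assay, with a range from 12000 nM to 80000 nM.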

Compound 3, half-maximal inhibitory concentration: 28600 nM
Estimate against measurement, compound 3: 1.1-fold (0.05 log units) above; the measured number falls inside the stated range.
By their numbers in this assay, from the lowest: compounds 1, 3 and 2 (each within the scatter of the next).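

For the compounds shown here, compound 3 gives the first reading of the methyl on its own: in this assay, methyl in place of hydrogen on an aromatic carbon, para to a large group, gives a 1.4-fold lower number from compound 2 to compound 3 (0.15 log units; within the scatter) and so does not separate the two compounds. Going by these compounds alone, the same compound also gives the first reading of the other place on its own, where bromo in place of tert-butyl on an aromatic carbon gives a 1.1-fold higher number from compound 1 to compound 3 (0.04 log units; within the scatter) and leaves these two groups indistinguishable in this read-out. No measurement is available that would explain why either change leaves the number within the scatter.

All three compounds lie within the scatter of their neighbours, so the compounds shown leave open whether any change at either place can move the number beyond it. A hydroxyl, an amine or a carboxylic acid in place of the methyl or the bromo, or a longer chain at either place, remains an open case, and so does the effect of altering the shared core.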